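A few compounds are considered here, and "the series" means these few. Any claim that something is new, unique, unknown or untested is made for them only; others in the source may bear on it.

Compound 1, `CCCCCCCCCCCCn1nnc(C(NC(=O)c2ccc(OC)cc2)c2ccccc2)n1`: 600 nM
Compound 2, `CCCCCCCCCCCCn1nnc(C(NC(=O)c2ccc(C)cc2)c2ccccc2)n1`: 510 nM

Both compounds were tested in an assay on microsomes from liver for inhibition of sterol O-acyltransferase 1 (Rattus norvegicus); on this read-out lower numbers stand for stronger inhibition and higher numbers for weaker inhibition. Compound 2 gives 510 nM in this assay, and compound 1 gives 600 nM; the two numbers lie within the scatter of each other, as the step of a 1.2-fold lower number from compound 1 to compound 2 (0.07 log units; within the scatter) shows, so neither compound can be set apart from the other on these data.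

The next compound, compound 3, `CCCCCCCCCCCCn1nnc(C(NC(=O)c2ccc(C(F)(F)F)cc2)c2ccccc2)n1`, is not yet measured in this assay. It differs from compound 2 in one place: trifluoromethyl in place of methyl on an aromatic carbon. Going by the values given here, the only measured step that touches this position is the one from methoxy to methyl, a 1.2-fold lower number from compound 1 to compound 2 (0.07 log units; within the scatter), which stayed within the scatter. Two substituents at this position therefore gave numbers that cannot be told apart, and nothing more is known about what a third one does there. On that basis compound 3 is expected to stay close to compound 2, with the step of a 1.3-fold lower number from compound 2 to compound 3 (0.11 log units; within the scatter) estimated to lie inside or only just beyond the scatter. Compound 3 is estimated at 400 nM, in a range from 150 nM to 1100 nM.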

Compound 3, half-maximal inhibitory concentration: 850 nM
Estimate against measurement, compound 3: 2.1-fold (0.33 log units) below; the measured number falls inside the stated range.
By their numbers in this assay, from the lowest: compounds 2, 1 and 3 (each within the scatter of the next).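

In this assay the step of a 1.7-fold higher number from compound 2 to compound 3 (0.22 log units; within the scatter) and the step of a 1.4-fold higher number from compound 1 to compound 3 (0.15 log units; within the scatter) show that a third substituent on this aromatic carbon, para to a large group, also gives a number that cannot be set apart from the others. The earlier pair covered only methoxy and methyl, whereas this result extends the finding to trifluoromethyl, so that four heavy atoms entering in place of one, in the change from 4-methylphenyl to 4-(trifluoromethyl)phenyl, still leave the number within the scatter. No supporting evidence bears on this result, and the three numbers are all there is to go on.

The compounds shown leave open whether a group of another kind at this place, such as an amine or a carboxylic acid, would give a number beyond the scatter, and whether any of these substituents would behave alike elsewhere on the ring. They also leave open what happens when the rest of the shared core changes, for example when a shorter chain replaces the long alkyl chain or when the amide hydrogen is replaced by a methyl group.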